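The source may report more compounds than this note shows. Statements on the series, on what has been measured and on what is new or still open speak of the compounds shown alone.

Measured in a functional assay on MDA-MB-468 cells (Homo sapiens) for antiproliferative activity, read by MTT assay, with a stated time of 72 h; a higher number here means a weaker inhibitor, a lower number a stronger inhibitor:
Compound 1 `CCCn1ccnc1-c1cc(OC)c(OC)c(OC)c1`: > 100000 nM
Compound 2 `COc1cc(-c2nccn2-c2ccc(F)cc2)cc(OC)c1OC`: 62200 nM

The entry for compound 1 is a limit of the assay and not a number. For the measured compounds named here, compound 2, at 62200 nM, has the only true number so far. Compound 3 `COc1cc(-c2nccn2-c2ccc(Br)cc2)cc(OC)c1OC` differs from it in one place: bromo in place of fluoro on an aromatic carbon. Going by the values given here, the one measured step, an at least 1.6-fold lower number from compound 1 to compound 2 (0.20 log units; that floor lies within the scatter), changes a different group and rests on (the limit of > 100000 nM in this assay, at which 1 of the 2 values shown sits), so it gives little guidance here. No step beyond the scatter is therefore expected in this assay, and the expected change is a 1.2-fold lower number from compound 2 to compound 3 (0.09 log units; within the scatter). For compound 3 the estimated value is 50000 nM, with an expected range of 15000 nM to 120000 nM.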

Compound 3, half-maximal inhibitory concentration: 2700 nM
Beside the measured number, compound 3's estimate is 19-fold (1.27 log units) above it, and the stated range ends above it.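

At this position, on an aromatic carbon para to a large group, a single atom decides much of the activity: bromo in place of fluoro gives a 23-fold lower number from compound 2 to compound 3 (1.36 log units; beyond the scatter) in this assay. Replacing propyl with 4-bromophenyl on the aromatic nitrogen gives an at least 37-fold lower number from compound 1 to compound 3 (1.56 log units; beyond the scatter). That step is only a floor, because the entry for compound 1 is a limit of the assay: the limit of > 100000 nM in this assay, at which 1 of the 3 values shown sits.

The compounds shown leave open whether chloro or iodo on this carbon would match bromo, and whether a methyl or methoxy group would do the same. They give no reason for the large step.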